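Removing the sulfonamide from the cyclohexyl ring

The compounds below may be only part of what the source reports. "The series", "measured", "known", "first", "only" and "open" are said of these compounds alone.

Compound 2 `O=c1cc(N2CCN(CC3CCC(NS(=O)(=O)c4ccccc4)CC3)CC2)sc2c([N+](=O)[O-])cc(C(F)(F)F)cc12` gives 95.3% in an ADME assay on cells (Hepatocyte, Mus musculus) for metabolic stability, with a stated time of 30 min (on this read-out lower numbers stand for a less stable compound and higher numbers for a more stable compound), and stands lowest of the two measured numbers; its nearest neighbour is compound 1 `NC1CCC(CN2CCN(c3cc(=O)c4cc(C(F)(F)F)cc([N+](=O)[O-])c4s3)CC2)CC1`, which gives 107%. Going by the values given here, the one measured step, a number 11.7 percentage points lower from compound 1 to compound 2 (beyond the scatter), is modest. Compound 3 `O=c1cc(N2CCN(CC3CCCCC3)CC2)sc2c([N+](=O)[O-])cc(C(F)(F)F)cc12` carries the change (hydrogen in place of (phenylsulfonyl)amino on a saturated ring carbon). Among the compounds with values here, no measured step mirrors this loss of the whole group; only the step from compound 1 to compound 2 bears on it, in the opposite sense and only partly. Compound 3 is therefore expected to show a modest rise, a number 4.7 percentage points higher from compound 2 to compound 3 (within the scatter), to an estimated 100% with a range from 82% to 112%.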

Compound 3, percent of the compound remaining: 80.6%
For compound 3 the middle estimate is 19.4 percentage points above the measured one; measured number below the stated range.
By their numbers in this assay, from the lowest: compound 3; then compound 2; then compound 1.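

In this assay the bare saturated ring carbon turns out to be the least stable case so far: there is a number 14.7 percentage points lower from compound 2 to compound 3 (beyond the scatter) and also a number 26.4 percentage points lower from compound 1 to compound 3 (beyond the scatter) in the same direction. Both the amino and the (phenylsulfonyl)amino groups thus stand above hydrogen at this place, which the step between those two compounds could not show. Nothing measured here explains this difference. Going by these compounds, it remains open whether a hydroxyl group, a carboxylic acid or an acetamide on this ring carbon would also stand above compound 3 80.6% in this assay.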